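This account rests on a few compounds, and the source may have more. Where it says the series, first, only, none or still open, it means among the compounds named here.

Series notes. The shared core carries a 4-(methylsulfanyl)phenyl group and varies the aryl group on the double-bonded ring carbon. Compound 1 `CSc1ccc(C2=C(c3ccc(F)c(F)c3)C(=O)N3CCCC3C2)cc1` gives 200 nM in a functional assay on SW-620 cells (Homo sapiens) for cytotoxicity; on this read-out higher numbers stand for weaker inhibition of growth and lower numbers for stronger inhibition of growth. Compound 2 `CSc1ccc(C2=C(c3ccc(F)c(C)c3)C(=O)N3CCCC3C2)cc1` gives 600 nM in this assay. Compound 3 `CSc1ccc(C2=C(c3ccc(C)cc3)C(=O)N3CCCC3C2)cc1` gives 3000 nM in this assay, the highest number of the three measured, with the step of a 15-fold higher number from compound 1 to compound 3 (1.18 log units; beyond the scatter) and the step of a 5.0-fold higher number from compound 2 to compound 3 (0.70 log units; beyond the scatter) both beyond the scatter.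

Compound 4 `CSc1ccc(C2=C(c3ccc(F)cc3)C(=O)N3CCCC3C2)cc1` is not yet measured in this assay. It is related to compound 3 by fluoro in place of methyl on an aromatic carbon. The same change, fluoro in place of methyl on an aromatic carbon, occurs once among the measured compounds as fluoro in place of methyl on an aromatic carbon, where it produced a 3.0-fold lower number from compound 2 to compound 1 (0.48 log units; beyond the scatter). The two cores differ by 4-methylphenyl in place of 4-fluoro-3-methylphenyl on a double-bonded ring carbon. The surroundings of the place are not identical: in the measured pair the carbon is ortho to a fluoro group and meta to a large group, while in compound 3 it is para to a large group, so this is the same kind of change rather than the same change.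

Among the measured compounds shown here, for compound 4 a step of about a 3.0-fold lower number from compound 3 to compound 4 (0.48 log units; beyond the scatter) in this assay is expected, resting on the single precedent a 3.0-fold lower number from compound 2 to compound 1 (0.48 log units; beyond the scatter), read with some caution given the different surroundings. Compound 4 is therefore estimated at 1000 nM in this assay, with a plausible span from 350 nM to 3000 nM.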

Compound 4, concentration for 50% growth inhibition: 500 nM
Compound 4: the middle estimate sits 2.0-fold (0.30 log units) above what was measured, within the range that was stated.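

Fluoro in place of methyl on an aromatic carbon gives a lower number on both cores in this assay, and the two steps do not differ beyond the scatter: the same change on two cores in this assay, a 3.0-fold lower number (0.48 log units; beyond the scatter) from compound 2 to compound 1 and a 6.0-fold lower number (0.78 log units; beyond the scatter) from compound 3 to compound 4, 2.0-fold (0.30 log units) apart, within the scatter of two such steps

On the core of compound 3, the change para to a large group gives a 6.0-fold lower number from compound 3 to compound 4 (0.78 log units; beyond the scatter), so the direction of the change carried over between these two cores, but two pairs do not fix a size for the step or show that it will hold on any further core. The neighbouring hydrogen-for-methyl and hydrogen-for-fluoro steps add to this picture without explaining it: a 1.2-fold lower number from compound 2 to compound 4 (0.08 log units; within the scatter) is within the scatter, so compound 2 and compound 4 cannot be told apart in this assay, while a 2.5-fold higher number from compound 1 to compound 4 (0.40 log units; beyond the scatter) is beyond it, and these single pairs say nothing about why the steps differ.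

The compounds shown leave open whether a chloro group, a methoxy group or an amine on the same aromatic carbon would fall in line with fluoro or with methyl. They also leave open whether the fluoro-for-methyl step survives when the 4-(methylsulfanyl)phenyl group of the shared core is replaced, for instance by a 4-methoxyphenyl group.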